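Seven-Membered Amine Ring in Place of Piperazine: Stability Outlook

This account rests on a few compounds, and the source may have more. Where it says the series, first, only, none or still open, it means among the compounds named here.

Compound 1 `c1cncc(-c2cc3c(-c4cccc(N5CCNCC5)n4)n[nH]c3cn2)c1` was examined in an ADME assay on microsomes from intestine (Rattus norvegicus) for metabolic stability, with NADPH named in the record, with a stated time of 60 min, in the absence of a further agent (on this read-out higher numbers stand for a more stable compound and lower numbers for a less stable compound), where compound 1 is recorded as "stable" (no number reported) without a single number attached to it. Two related compounds do give numbers on the same read-out: compound 2 `Cn1cc(-c2cc3c(-c4cccc(N5CCC[C@H](N)C5)n4)nn(C)c3cn2)cn1` gives 95%, and compound 3 `CCn1cc(-c2cc3c(-c4cccc(N5CCN(C)CC5)n4)n[nH]c3cn2)cn1` gives 82%. Compound 4 `c1cncc(-c2cc3c(-c4cccc(N5CCCNCC5)n4)n[nH]c3cn2)c1` differs from compound 1 in one place: 1,4-diazepan-1-yl in place of piperazin-1-yl on an aromatic carbon. Among the measured compounds shown here, no measured pair covers this change, so the size of the step in this assay cannot be taken from any neighbours; with compound 1 described only as stable and its two relatives high on the read-out, no shift beyond the scatter is expected in either direction. Compound 4 is therefore expected to come out at 85%, within 65% to 97%.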

Compound 4, percent of the compound remaining: "stable" (no number reported)
No number was reported for compound 4, so the estimate cannot be set against anything.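

In this assay, among the compounds shown here, compound 1 gives "stable" (no number reported) and compound 4 gives "stable" (no number reported), so no step between them can be read. The compounds shown leave open how large any shift from piperazin-1-yl to 1,4-diazepan-1-yl is. Nothing shown bears on a cause.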